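Hydroxamate series: swapping the amide substituent in compound 2

The source may hold more compounds than are shown below. What is called first, only, known or untested is meant among the compounds shown, and "the series" means these compounds.

Three compounds of this series carry a measured value. Compound 1 `Cc1ccc(NC(=O)CCN(Cc2ccc(C(=O)NO)cc2)C(=O)c2cc(C)cc(C)c2)cc1` gives 370 nM in a functional assay on G55T2 cells (Homo sapiens) for antiproliferative activity, read by WST assay, with a stated time of 72 h; a higher number here means a weaker inhibitor, a lower number a stronger inhibitor. Compound 2 `CN(C)c1ccc(C(=O)N(CCC(=O)NCc2ccc(Cl)cc2)Cc2ccc(C(=O)NO)cc2)cc1` gives 460 nM in this assay, which places it second highest of the three numbers; the value of compound 1 sits within the scatter of that of compound 2, so the two cannot be told apart. Compound 3 `COc1ccc(C(=O)N(CCC(=O)NCc2ccccc2)Cc2ccc(C(=O)NO)cc2)cc1` gives 3490 nM in this assay, a number beyond the scatter above that of compound 2, so compound 3 is the weaker inhibitor of the pair.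

Compound 4 `Cc1ccc(NC(=O)CCN(Cc2ccc(C(=O)NO)cc2)C(=O)c2ccc(N(C)C)cc2)cc1` has not been measured. It differs from compound 2 in one place: 4-methylphenyl in place of 4-chlorobenzyl on an amide-type nitrogen. The place is an amide-type nitrogen whose other neighbours are a carbonyl carbon. Among the compounds with values here, no step between two measured compounds covers this change, so no measured step can be quoted for it.

The expectation for compound 4 is a step no larger than the scatter, a 1.3-fold lower number from compound 2 to compound 4 (0.12 log units; within the scatter), in either direction, because compound 1 also carries the 4-methylphenyl on that nitrogen and gives 370 nM. Compound 4 is therefore estimated at 350 nM, within a range from 150 nM to 800 nM.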

Compound 4, half-maximal inhibitory concentration: 330 nM
Estimate against measurement, compound 4: 1.1-fold (0.03 log units) above, and the stated range covers the measured number.
By their numbers in this assay, from the lowest: compounds 4, 1 and 2 (each within the scatter of the next); then compound 3.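

Within the data shown here, these are the first single-place comparisons. In this assay, the swap on the amide-type nitrogen gives a 1.4-fold lower number from compound 2 to compound 4 (0.14 log units; within the scatter), so with 4-(dimethylamino)phenyl on the carbonyl carbon, this nitrogen accepts 4-methylphenyl in place of 4-chlorobenzyl with no readable change in the number, even though the two groups differ in the way they are attached to that nitrogen. The second comparison gives a 1.1-fold lower number from compound 1 to compound 4 (0.05 log units; within the scatter), so with 4-methylphenyl on the nitrogen, the carbonyl carbon likewise shows no readable change on going from 3,5-dimethylphenyl to 4-(dimethylamino)phenyl, and no data on hand offer an explanation for either result.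

Compound 3 at 3490 nM differs from each of the other compounds in more than one place, so its steps cannot be read and its higher number cannot be assigned to either substituent. Also open, as far as these compounds go, is whether the number would hold with a phenethyl group, a cyclohexyl group or a chain carrying a carboxylic acid on that amide-type nitrogen.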